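Replacing a halogenated aryl on compound 3's ring nitrogen

A few compounds are considered here, and "the series" means these few. Any claim that something is new, unique, unknown or untested is made for them only; others in the source may bear on it.

Of the compounds shown here, three sharing one core have been measured in a functional assay on HepG2 cells (Homo sapiens) for inhibition, read by MTT assay, with a stated time of 72 h; on this read-out lower numbers stand for stronger inhibition and higher numbers for weaker inhibition. Compound 1 `COc1ccc(-n2cc(C(=O)Nc3ccc(Oc4ccnc5c4ccn5C)c(F)c3)c(=O)c3ccccc32)cc1` gives 3750 nM, compound 2 `O=C(Nc1ccc(Oc2ccnc3[nH]ccc23)c(F)c1)c1cn(-c2ccc(F)cc2)c2ccccc2c1=O` gives 270 nM, and compound 3 `O=C(Nc1ccc(Oc2ccnc3[nH]ccc23)c(F)c1)c1cn(-c2ccc(C(F)(F)F)cc2Cl)c2ccccc2c1=O` gives 1840 nM. On these numbers compound 3 stands second highest of the three: compound 1 lies a step above it, and compound 2 lies well below it. Among the measured compounds shown here, the only single-point step among the measured compounds is a 6.8-fold higher number from compound 2 to compound 3 (0.83 log units; beyond the scatter), so going from 4-fluorophenyl to the larger chlorinated, trifluoromethylated phenyl raised the number clearly.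

Compound 4 `COc1ccc(-n2cc(C(=O)Nc3ccc(Oc4ccnc5[nH]ccc45)c(F)c3)c(=O)c3ccccc32)cc1` is reached from compound 3 by the change (4-methoxyphenyl in place of 2-chloro-4-(trifluoromethyl)phenyl on an aromatic nitrogen). It returns to a small para-substituted phenyl resembling that of compound 2, and it carries the same 4-methoxyphenyl as compound 1, though compound 1 differs from it elsewhere. The step from compound 2 to compound 3 is the one that bears on this change, and it was modest in size. Reversing that kind of change, compound 4 is expected to show a lower number in this assay than compound 3, with the expected step being a 3.1-fold lower number from compound 3 to compound 4 (0.49 log units; beyond the scatter). For compound 4 the estimate in this assay is 600 nM, within a range of 150 nM to 2500 nM.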

Compound 4, half-maximal inhibitory concentration: 6530 nM
The estimate for compound 4 lay 11-fold (1.04 log units) below the measured number, and the stated range ends below it.
By their numbers in this assay, from the lowest: compound 2; then compound 3; then compounds 1 and 4 (each within the scatter of the next).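

In this assay, among the compounds shown here, the aryl group on this ring nitrogen does not order the numbers by size: 4-methoxyphenyl has fewer heavy atoms than 2-chloro-4-(trifluoromethyl)phenyl, yet putting it in its place gives a 3.5-fold higher number from compound 3 to compound 4 (0.55 log units; beyond the scatter) and methoxy in place of fluoro on the aromatic carbon gives a 24-fold higher number from compound 2 to compound 4 (1.38 log units; beyond the scatter), the largest step seen at this position, so the single group on that phenyl matters more here than the overall size of the aryl. The change of hydrogen in place of methyl on the other aromatic nitrogen gives a 1.7-fold higher number from compound 1 to compound 4 (0.24 log units; within the scatter) and so shows no measurable effect, which means that the high numbers of both 4-methoxyphenyl compounds stay with the aryl group and not with that methyl. Nothing available explains this order of the three aryl groups.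

The compounds shown leave open where a phenyl carrying an amine, a carboxylic acid or a longer alkoxy chain would fall relative to the 4-fluorophenyl of compound 2. They also leave open whether chlorine and trifluoromethyl each raise the number on their own, since the two enter together in compound 3.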